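The compounds below may be only part of what the source reports. "The series", "measured", "known", "first", "only" and "open" are said of these compounds alone.

Measured compounds in a functional assay on MCF7 cells (Homo sapiens) for inhibition, read by MTT assay, with a stated time of 72 h; a higher number here means a weaker inhibitor, a lower number a stronger inhibitor:

Compound 1, `Cc1ccc(Cn2cc(CSC(=S)N3CCN(C(=O)OCc4ccccc4)CC3)nn2)cc1`, gives 37800 nM.
Compound 2, `O=C(OCc1ccccc1)N1CCN(C(=S)SCc2cn(Cc3ccc(F)cc3)nn2)CC1`, gives 10300 nM.
Compound 3, `COc1cc(Cn2cc(CSC(=S)N3CCN(C(=O)OCc4ccccc4)CC3)nn2)cc(OC)c1OC`, gives only a limit of the assay, > 128000 nM.

Three compounds share one core and differ only in the group carried on the chain carbon bound to the aromatic nitrogen. Compound 3 stands at the weak end of what has been measured: it gives no number, only a limit, as noted in the limit of > 128000 nM in this assay, at which 1 of the 3 values shown sits. Going from compound 1 to compound 2 brought a 3.7-fold lower number from compound 1 to compound 2 (0.56 log units; beyond the scatter), while the trimethoxyphenyl group cost an at least 3.3-fold higher number from compound 1 to compound 3 (0.52 log units; beyond the scatter) and an at least 12-fold higher number from compound 2 to compound 3 (1.09 log units; beyond the scatter).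

Compound 4, `COc1cc(Cn2cc(CSC(=S)N3CCN(C(=O)OC(C)(C)C)CC3)nn2)cc(OC)c1OC`, keeps the trimethoxyphenyl group of compound 3 and changes a different part of the molecule: tert-butyl in place of benzyl on an oxygen next to a carbonyl group

For the measured compounds named here, none of the measured steps touches the group on the oxygen next to the carbonyl, so no step bears directly on this change. All three measured steps concern the other end of the molecule, and their sizes say nothing about this one. In the absence of any evidence, the expectation for compound 4 in this assay is a step that the limit leaves unreadable from compound 3 to compound 4, with no movement beyond the scatter foreseen. Compound 4 is therefore expected to give about 150000 nM, within a range from 40000 nM to 600000 nM, and most likely again only a limit.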

Compound 4, half-maximal inhibitory concentration: 22700 nM
Compound 4: middle estimate off by 6.6-fold (0.82 log units), on the high side; the measured number lies below the stated range.
By their numbers in this assay, from the lowest: compound 2; then compounds 4 and 1 (each within the scatter of the next). At a limit, above all of these: compound 3.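

In this assay, tert-butyl in place of benzyl on an oxygen next to a carbonyl group brought an at least 5.6-fold lower number from compound 3 to compound 4 (0.75 log units; beyond the scatter), the first sign that this end of the molecule also moves the number, since every earlier step concerned only the group on the chain carbon bound to the aromatic nitrogen. The trimethoxyphenyl group therefore does not by itself rule out a measurable number, for compound 4 carries that group and gives a true reading of 22700 nM. On these data alone, the full size of the step stays unknown because compound 3 has a limit and not a number: the limit of > 128000 nM in this assay, at which 1 of the 4 values shown sits.

Tert-butyl appears here only together with the trimethoxyphenyl group, so it remains open whether the same change would lower the number to a similar degree in compounds carrying 4-methylphenyl or 4-fluorophenyl. Also open, as far as these compounds go, is how a small methyl or a saturated cyclohexyl ring on that oxygen would read, which would help to tell whether the gain depends on losing the benzyl group or on having tert-butyl in its place.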